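This account rests on a few compounds, and the source may have more. Where it says the series, first, only, none or still open, it means among the compounds named here.

Compound 1 `Cc1ccccc1-n1nncc1CN1C(=O)C2(C(C#N)=C(N)Oc3c2c2nc4ccccc4nc2c2ccccc32)c2ccccc21`: in a functional assay on MCF7 cells (Homo sapiens) for antiproliferative activity, read by MTT assay, with a stated time of 48 h (on this read-out lower numbers stand for stronger inhibition and higher numbers for weaker inhibition), compound 1 gives > 50000 nM, which is a limit of the assay and not a number.
Compound 2 `N#CC1=C(N)Oc2c(c3nc4ccccc4nc3c3ccccc23)C12C(=O)N(Cc1cnnn1-c1cccc(Br)c1)c1ccccc12`: in this assay compound 2 gives > 50000 nM, again a limit.
Compound 3 `N#CC1=C(N)Oc2c(c3nc4ccccc4nc3c3ccccc23)C12C(=O)N(Cc1cnnn1-c1cccc(S(N)(=O)=O)c1)c1ccccc12`: in this assay compound 3 gives 42500 nM.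

Within the data shown here, compound 3 therefore holds the only number among the three; the other two sit at the limit (the limit of > 50000 nM in this assay, at which 2 of the 3 values shown sit). Compound 4 `Cc1ccc(-n2nncc2CN2C(=O)C3(C(C#N)=C(N)Oc4c3c3nc5ccccc5nc3c3ccccc43)c3ccccc32)c(C)c1` differs from compound 3 by 2,4-dimethylphenyl in place of 3-sulfamoylphenyl on an aromatic nitrogen. Among the measured compounds shown here, two measured steps touch this change: an at least 1.1-fold lower number from compound 1 to compound 3 (0.07 log units; that floor lies within the scatter) and an at least 1.1-fold lower number from compound 2 to compound 3 (0.07 log units; that floor lies within the scatter), and both are only floors that lie within the scatter, so neither shows a real change. The step that the two limits leave unreadable from compound 1 to compound 2 cannot be read at all. The 2,4-dimethylphenyl of compound 4 resembles the 2-methylphenyl of compound 1 more than the 3-sulfamoylphenyl of compound 3, and compound 1 sits at the limit (the limit of > 50000 nM in this assay, at which 2 of the 3 values shown sit), so compound 4 is expected to move back toward that limit, with the step of a 1.4-fold higher number from compound 3 to compound 4 (0.15 log units; within the scatter) expected to stay small in this assay. Compound 4 is estimated at 60000 nM, in a range from 30000 nM to 150000 nM, most likely reported as a limit.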

Compound 4, half-maximal inhibitory concentration: > 50000 nM
Compound 4 was reported as a limit (the forecaster's own chance of this, stated with the estimate: 70%); the middle value is on the limit's open side.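

Placing 2,4-dimethylphenyl on the aromatic nitrogen in place of 3-sulfamoylphenyl gives an at least 1.1-fold higher number from compound 3 to compound 4 (0.07 log units; that floor lies within the scatter), so in this assay the change from the sulfamoyl-bearing ring to a ring carrying only methyl groups shows no real change. The steps from compound 1 and from compound 2 to compound 4 cannot be read, as both ends of each are limits. The new result adds one more substituted phenyl ring at this position to those at the limit, which now holds most of the set: the limit of > 50000 nM in this assay, at which 3 of the 4 values shown sit.

With only compound 3 giving a number, the compounds shown cannot rank the groups at this position. On these data alone, whether an amine or a carboxylic acid on the phenyl ring, or a longer chain in its place, would give a clearly lower number stays open.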